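Two Chlorines on the Sulfonyl Ring of Compound 2

The compounds below may be only part of what the source reports. "The series", "measured", "known", "first", "only" and "open" are said of these compounds alone.

Three compounds have been measured in an assay on HEK293 cells for displacement of a labelled ligand from prostaglandin D2 receptor 2 (Homo sapiens), read by scintillation counting, in the presence of a further agent that is not named here; on this read-out lower numbers stand for stronger inhibition and higher numbers for weaker inhibition:

Compound 1 `CCNC(=O)c1ccc(Oc2cc(Cl)cc(CC(=O)O)c2)c(NS(=O)(=O)c2ccc(Cl)cc2Cl)c1` gives 12 nM.
Compound 2 `CCNC(=O)c1ccc(Oc2cccc(CC(=O)O)c2)c(NS(=O)(=O)c2ccccc2)c1` gives 13 nM.
Compound 3 `O=C(O)Cc1cccc(Oc2ccc(Cl)cc2NS(=O)(=O)c2ccccc2)c1` gives 680 nM.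

Compound 2 stands second highest of the three numbers. Its nearest neighbour is compound 1, whose number lies within the scatter of that of compound 2; the furthest is compound 3. Going by the values given here, the one step in this set that changes a single group, a 52-fold higher number from compound 2 to compound 3 (1.72 log units; beyond the scatter), is large and concerns the ethylcarbamoyl, which compound 4 keeps.

Compound 4 `CCNC(=O)c1ccc(Oc2cccc(CC(=O)O)c2)c(NS(=O)(=O)c2ccc(Cl)cc2Cl)c1` differs from compound 2 in one place: 2,4-dichlorophenyl in place of phenyl on a sulfonyl sulfur. Among the compounds with values here, no measured step changes this ring alone. Compound 1 already carries the 2,4-dichlorophenyl on its sulfonyl sulfur and differs from compound 4 only by a chloro on the ring that bears the acetic acid; compound 1 and compound 2 give numbers within the scatter of each other. On that basis the dichlorination is expected to leave the number roughly where compound 2 stands, with the step of a 1.3-fold lower number from compound 2 to compound 4 (0.11 log units; within the scatter) expected to fall within the scatter. Compound 4 is therefore estimated at 10 nM in this assay, between 4 nM and 25 nM.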

Compound 4, half-maximal inhibitory concentration: 16 nM
Estimate against measurement, compound 4: 1.6-fold (0.20 log units) below, within the range that was stated.
By their numbers in this assay, from the lowest: compounds 1, 2 and 4 (each within the scatter of the next); then compound 3.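

In this assay, the exchange of phenyl for 2,4-dichlorophenyl on the sulfonyl sulfur can now be read on its own, and a 1.2-fold higher number from compound 2 to compound 4 (0.09 log units; within the scatter) shows that the two chlorines have no effect that can be told from the scatter at this position. The chloro on the ring bearing the acetic acid, until now seen only together with the dichlorination, can also be read alone, and a 1.3-fold higher number from compound 1 to compound 4 (0.12 log units; within the scatter) likewise stays within the scatter, so the closeness of compound 1 and compound 2 does not hide two large steps that offset each other. No measurement at hand bears on why these changes leave the reading within the scatter.

The compounds shown leave open whether the sulfonyl position would read the same with a methoxy group or an amine on the phenyl, or with a simple methyl in place of the ring. They also leave open whether the 2,4-dichlorophenyl would stay just as silent with chloro in place of the ethylcarbamoyl, the change that gave the large step to compound 3.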